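The source may report more compounds than this note shows. Statements on the series, on what has been measured and on what is new or still open speak of the compounds shown alone.

In a functional assay on MCF7 cells (Homo sapiens) for cytotoxicity, read by MTT assay, with a stated time of 72 h (a lower number here means a stronger inhibitor, a higher number a weaker inhibitor), compound 1 `CN(C)c1ccc(C=C2C(=O)N(c3ccc(Cl)cc3)N(c3ccc(Cl)cc3)C2=O)cc1` reads > 128000 nM, which is a limit of the assay and not a number. For the measured compounds named here, the only true number on the shared core comes from compound 2 `COc1cc(C=C2C(=O)N(c3ccc(Cl)cc3)N(c3ccc(Cl)cc3)C2=O)cc(OC)c1OC`, at 16200 nM. Compound 3 `COc1cc(C=C2C(=O)N(c3ccc(Cl)cc3)N(c3ccc(Cl)cc3)C2=O)ccc1O` has 4-hydroxy-3-methoxyphenyl in place of 4-(dimethylamino)phenyl on a double-bonded chain carbon bound to a double-bonded ring carbon. With compound 2 at 16200 nM as the guide, stronger inhibition is expected, an estimated at least 5.1-fold lower number from compound 1 to compound 3 (0.70 log units; beyond the scatter). Compound 3 is expected at about 25000 nM, with an estimated range of 8000 nM to 80000 nM.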

Compound 3, half-maximal inhibitory concentration: 22800 nM
Beside the measured number, compound 3's estimate is 1.1-fold (0.04 log units) above it; the measured number falls inside the stated range.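

In this assay, 4-hydroxy-3-methoxyphenyl in place of 4-(dimethylamino)phenyl on a double-bonded chain carbon bound to a double-bonded ring carbon gives an at least 5.6-fold lower number from compound 1 to compound 3 (0.74 log units; beyond the scatter). This gives the position a direct one-place comparison, and it shows that the group held there can move the read-out on the shared core. Only the lower bound of that change can be read, since compound 1 stands at a limit of the assay and not at a number: the limit of > 128000 nM in this assay, at which 1 of the 3 values shown sits.

The compounds shown leave open whether the hydroxy or the methoxy group of compound 3 carries the change, and how a phenyl bearing a carboxylic acid or a primary amine would read at this position.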